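A few compounds are considered here, and "the series" means these few. Any claim that something is new, unique, unknown or untested is made for them only; others in the source may bear on it.

Measured so far:
compound 1 `O=C(O)c1cc(N2C(=O)C3=C(CCCC3)C2=O)c(F)cc1Cl` — 1000 nM
compound 2 `O=C(O)c1cc(N2C(=O)C3=C(CCCC3)C2=O)ccc1Cl` — a limit of the assay, > 100000 nM
compound 3 `CC(C)OC(=O)c1cc(N2C(=O)C3=C(CCCC3)C2=O)c(F)cc1Cl` — 13.8 nM

In a functional assay on the whole organism for inhibition, with Scenedesmus acutus as the target (a higher number here means a weaker inhibitor, a lower number a stronger inhibitor), compound 1 gives 1000 nM, the highest of the two numbers shown; the nearest is compound 3, which gives 13.8 nM. For compound 2 the assay reports only a limit, > 100000 nM, and no number. Two steps from compound 1 are known. The change hydrogen in place of fluoro on an aromatic carbon gives an at least 100-fold higher number from compound 1 to compound 2 (2.00 log units; beyond the scatter). The change isopropyl in place of hydrogen on an oxygen next to a carbonyl group gives a 72-fold lower number from compound 1 to compound 3 (1.86 log units; beyond the scatter).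

Compound 4 `CCCCOC(=O)c1cc(N2C(=O)C3=C(CCCC3)C2=O)c(F)cc1Cl` differs from compound 1 by butyl in place of hydrogen on an oxygen next to a carbonyl group. Within the data shown here, of the two measured steps only the one to compound 3 bears on it: the same place is changed, from hydrogen to an alkyl group, and there the number fell by a 72-fold lower number from compound 1 to compound 3 (1.86 log units; beyond the scatter). A step of similar size and in the same direction is therefore expected for compound 4, roughly a 67-fold lower number from compound 1 to compound 4 (1.82 log units; beyond the scatter). Compound 4 is thus estimated at 15 nM, within 4 nM to 60 nM.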

Compound 4, half-maximal inhibitory concentration: 126 nM
For compound 4 the middle estimate is 8.4-fold (0.92 log units) below the measured one, and the stated range ends below it.
By their numbers in this assay, from the lowest: compound 3; then compound 4; then compound 1. At a limit, above all of these: compound 2.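

In this assay butyl in place of hydrogen on the oxygen next to a carbonyl group also lowers the number (a 7.9-fold lower number from compound 1 to compound 4 (0.90 log units; beyond the scatter)), so the change at this oxygen goes the same way with a second alkyl group. The size of the gain depends on which alkyl group enters, and butyl falls short of isopropyl (a 9.1-fold higher number from compound 3 to compound 4 (0.96 log units; beyond the scatter)). No measurement shown accounts for this gap between the two esters.

Going by these compounds, it remains open where a methyl or ethyl ester, a longer chain such as hexyl, or a branched group such as tert-butyl would fall relative to isopropyl and butyl, and whether an amide at this place would follow the esters. Also open, on these data alone, is whether either ester keeps its number with hydrogen in place of fluoro on the aromatic carbon.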